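A few compounds are considered here, and "the series" means these few. Any claim that something is new, unique, unknown or untested is made for them only; others in the source may bear on it.

Compound 1 `N=C(N)NCCC[C@H](NC(=O)CN(c1nc(Cl)nc2[nH]cnc12)C1CC1)C(=O)O` and compound 2 `O=C(CN(c1ncnc2c1ncn2C1CCCCO1)C1CC1)NCC(=O)OCc1ccccc1` have both been run in a functional assay on the whole organism (Tail, strain ICR) with Mus musculus as the target, in the tail flick test, with a stated time of 30 min, at a dose of 25 umol/kg by the oral route; a higher number here means a stronger effect of the compound at the dose given, a lower number a weaker effect. Compound 1 gives 45.4% in this assay, the lowest of the two numbers; compound 2 gives 55.7%, a gap beyond the usual scatter. For the measured compounds named here, no measured pair differs in only one place, so no single step is known. Compound 3 `CC[C@H](C)[C@H](NC(=O)CN(c1nc(Cl)nc2[nH]cnc12)C1CC1)C(=O)O` is not yet measured; it differs from compound 1 as follows: a group of 4 heavy atoms (4 carbon; no ring) in place of a group of 7 heavy atoms (4 carbon, 3 nitrogen; no ring), on a saturated chain carbon bound to an amide-type nitrogen and a carbonyl carbon. Going by the values given here, with no measured step for such a change, the step expected here, a number 5.4 percentage points lower from compound 1 to compound 3 (within the scatter), is of uncertain direction and may not exceed the scatter. For compound 3 the estimate is 40%, with a range from 15% to 65%.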

Compound 3, a percentage reported as activity, at one dose (the size of the read-out at that dose, not a potency): 30.3%
For compound 3 the middle estimate is 9.7 percentage points above the measured one; the measured number falls inside the stated range.
By their numbers in this assay, from the lowest: compound 3; then compound 1; then compound 2.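

At this position, on a saturated chain carbon bound to an amide-type nitrogen and a carbonyl carbon, the side chain does affect the read-out in this assay: sec-butyl in place of the group of 7 heavy atoms gives a number 15.1 percentage points lower from compound 1 to compound 3 (beyond the scatter) on the shared core. A single step cannot separate the nitrogen atoms, the hydrogen-bond donors and the chain size as the part that counts, and nothing measured explains the drop.

Open, on these data alone, is where a primary amine, a carboxylic acid or a longer alkyl chain at this place would fall relative to compound 1 and compound 3.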